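This account rests on a few compounds, and the source may have more. Where it says the series, first, only, none or still open, it means among the compounds named here.

Three compounds of the series have been run in an ADME assay on Raji cells (Homo sapiens) for cytotoxicity, read by CellTiter-Glo and resazurin assay, with a stated time of 72 h (a higher number here means that more compound is needed for the effect, a lower number that less compound is needed), and none has given a number. Compound 1 `Cc1nnc(-c2cccc(-c3ccc(C(=O)N(Cc4cccc(OCCCCCC(=O)O)c4)C(C)C)cc3)c2)o1` reaches only the limit > 26000 nM in this assay. Compound 2 `CCOc1cccc(-c2ccc(C(=O)N(Cc3cccc(OCCCCCC(=O)O)c3)C(C)C)cc2)c1` likewise stops at the limit > 20800 nM in this assay. The step that the two limits leave unreadable from compound 1 to compound 2 cannot be sized; both of its ends are limits. Compound 3 `CCOC(=O)CCCCCOc1cccc(CN(C(=O)c2ccc(-c3cccc(NC(C)=O)c3)cc2)C(C)C)c1` also gives only the limit > 26000 nM in this assay. On the numbers shown, compound 3 stands with compound 1 at the limit of > 26000 nM in this assay, at which 2 of the 3 values shown sit, while compound 2 sits at the limit of > 20800 nM in this assay, at which 1 of the 3 values shown sits. Compound 4 `CCOC(=O)CCCCCOc1cccc(CN(C(=O)c2ccc(-c3ccc4c(c3)OCCO4)cc2)C(C)C)c1` differs from compound 3 by 2,3-dihydro-1,4-benzodioxin-6-yl in place of 3-acetamidophenyl on an aromatic carbon. For the measured compounds named here, no measured step in this assay bears directly on this change, and the single step that exists is unreadable. Nothing among the three measured compounds points to cytotoxicity appearing within the tested range, so compound 4 is expected to remain at the limit as well. Compound 4 is estimated at 26000 nM in this assay, with a range of 8000 nM to 60000 nM. The step of a number no higher from compound 3 to compound 4 (the limit leaves the size open) implied by this estimate is expected to be none beyond the scatter.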

Compound 4, half-maximal effective concentration: > 24400 nM
Compound 4: no number, only a limit; the forecaster's own chance of this, stated with the estimate: 80%; the middle value lies beyond the limit too.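

No new step can be read in this assay: compound 3 and compound 4 both stop at limits, so the swap of 3-acetamidophenyl for 2,3-dihydro-1,4-benzodioxin-6-yl cannot be sized. The compounds shown leave open at what concentration any of them would give an effect in this assay.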